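Trading Trifluoromethyl for Trifluoromethoxy: One Small Change

The source may hold more compounds than are shown below. What is called first, only, known or untested is meant among the compounds shown, and "the series" means these compounds.

Compound 1 `C[C@]1(O)C[C@@](c2ccnc(C(F)(F)F)c2)([C@H](O)c2ccccn2)C1`: 4270 nM
Compound 2 `O[C@H](c1ccccn1)[C@]1(c2cccc(C(F)(F)F)c2)C[C@H](O)C1`: 90 nM

In an assay on HEK293 cells for antagonist activity at transient receptor potential cation channel subfamily V member 3 (Homo sapiens), read by FLIPR and calcium flux (on this read-out lower numbers stand for stronger inhibition and higher numbers for weaker inhibition), compound 2 gives 90 nM, the lowest of the two numbers shown. Compound 1 gives 4270 nM, a gap well beyond the usual scatter. Compound 3 `O[C@H](c1ccccn1)[C@]1(c2cccc(OC(F)(F)F)c2)C[C@H](O)C1` is not yet measured and differs from compound 2 in one place: trifluoromethoxy in place of trifluoromethyl on an aromatic carbon. Among the measured compounds shown here, no measured pair shows this change, so the step in this assay is expected to be small, with no clear direction beyond the scatter. Compound 3 is therefore estimated at 120 nM, within a range from 40 nM to 400 nM. The expected step is a 1.3-fold higher number from compound 2 to compound 3 (0.12 log units; within the scatter).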

Compound 3, antagonist equilibrium constant: 40 nM
The estimate for compound 3 lay 3.0-fold (0.48 log units) above the measured number; the range from low to high includes it.
By their numbers in this assay, from the lowest: compound 3; then compound 2; then compound 1.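

At this place on the aromatic ring, meta to a large group, trifluoromethoxy in place of trifluoromethyl gives a 2.3-fold lower number from compound 2 to compound 3 (0.35 log units; beyond the scatter) in this assay as a modest step. The position therefore accepts the extra oxygen without any loss, and the change leads to stronger inhibition in this one pair. Nothing available here explains that gain.

A single pair cannot show whether the same change would help at another place on the ring or on another core. On these data alone, whether a nitrile or a methoxy group would do as well here also remains open.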